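The compounds below may be only part of what the source reports. "The series", "measured", "known", "first", "only" and "open" are said of these compounds alone.

Compound 1 `O=S(=O)(Nc1ccc(-c2nc3ccccc3o2)cc1)c1ccccc1Cl` is one of two sulfonamides tested in an ADME assay on HEK293 cells (Homo sapiens) for cytotoxicity, read by resazurin assay, with a stated time of 48 h; on this read-out higher numbers stand for lower toxicity in this test and lower numbers for higher toxicity in this test. For compound 1 the result is not a number but a limit of the assay, > 100000 nM. Compound 2 `O=S(=O)(Nc1ccc2oc(-c3ccccc3)nc2c1)c1cccc(O)c1` likewise reaches only a limit in this assay, > 100000 nM. Compound 1 thus sits at the limit of > 100000 nM in this assay, at which 2 of the 2 values shown sit, and nothing measured here separates it from the other compound.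

Compound 3 `O=S(=O)(Nc1ccc(-c2nc3ccccc3o2)cc1)c1ccc(F)cc1` differs from compound 1 in a single place: 4-fluorophenyl in place of 2-chlorophenyl on a sulfonyl sulfur. Among the compounds with values here, no measured pair of compounds here changes at that position, so the size of such a step cannot be read from the data; with both measured values resting at the limit, the expected step, a step that the limit leaves unreadable from compound 1 to compound 3, is none beyond the scatter. Compound 3 is therefore estimated to give about 150000 nM, somewhere between 50000 nM and 500000 nM, most likely again reported only as a limit.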

Compound 3, half-maximal cytotoxic concentration: > 100000 nM
Compound 3 was reported as a limit; the forecaster's own chance of this, stated with the estimate: 80%; the middle value lies beyond the limit too.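

No step can be read from compound 1 to compound 3, because both results are limits of the assay and not numbers: the limit of > 100000 nM in this assay, at which 3 of the 3 values shown sit. The compounds shown leave open at what concentration, if any, each would become toxic in this assay, and whether 4-fluorophenyl in place of 2-chlorophenyl alters that concentration.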